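Removing an Octyl Piece from Compound 1

This account rests on a few compounds, and the source may have more. Where it says the series, first, only, none or still open, it means among the compounds named here.

Cell toxicity is often checked early, to learn how much of a compound cultured cells tolerate. In an ADME assay on L929 cells (Mus musculus, culture collection number NCTC 929) for cytotoxicity, read by MTT assay, with a stated time of 72 h (a higher number here means a weaker inhibitor, a lower number a stronger inhibitor), compound 1 `CCCCCCCCCCCCCC(=O)c1c(O)cc(C)oc1=O` gives > 200000 nM, which is a limit of the assay and not a number. So compound 1 has only a limit here, with no exact value. A second compound with a different side group, compound 2 `Cc1cc(O)c(C(=S)NC2CCCCC2)c(=O)o1`, gives 177000 nM in this assay.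

Compound 3 `CCCCCC(=O)c1c(O)cc(C)oc1=O` keeps the shared core but shortens the chain of compound 1. The change is hydrogen in place of octyl on a saturated chain carbon, five bonds along the chain from a carbonyl carbon, with hydrogen in place of octyl on a saturated chain carbon, five bonds along the chain from a carbonyl carbon. For the measured compounds named here, no measured pair shows what such a change does. With compound 2 at 177000 nM, weak inhibition is expected to persist, with no shift beyond the scatter. The expected step is an at least 1.1-fold lower number from compound 1 to compound 3 (0.04 log units; that floor lies within the scatter). For compound 3 the estimated value is 180000 nM, within an expected range of 80000 nM to 300000 nM.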

Compound 3, half-maximal inhibitory concentration: > 200000 nM
Compound 3 was reported as a limit (the forecaster's own chance of this, stated with the estimate: 55%); middle value at least 1.1-fold (0.04 log units) away from the limit.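

Compound 1 and compound 3 both stop at a limit of this assay, so no step between them can be read: the limit of > 200000 nM in this assay, at which 2 of the 3 values shown sit.

The compounds shown leave open where compound 1 and compound 3 truly lie, and whether hydrogen in place of octyl shifts the number at all.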